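Trading an Azetidinyl Amide Chain for a Vinylcarbonyl

The source may hold more compounds than are shown below. What is called first, only, known or untested is meant among the compounds shown, and "the series" means these compounds.

Compound 3 `O=C(/C=C/CNCCOc1ccc(Oc2c(-c3ccc(F)cc3)sc3cc(O)ccc23)cc1)N1CCC1` holds the lowest of the two numbers in a functional assay on MCF7 cells (Homo sapiens) for antiproliferative activity, read by CCK-8 assay, with a stated time of 48 h (a lower number here means a stronger inhibitor, a higher number a weaker inhibitor), where compound 3 gives 7340 nM. Compound 1 `CN(C)C(=O)/C=C/CN1CC(Oc2ccc(Oc3c(-c4ccc(F)cc4)sc4cc(O)ccc34)cc2)C1` gives 22300 nM in this assay, and the step of a 3.0-fold lower number from compound 1 to compound 3 (0.48 log units; beyond the scatter) lies beyond the scatter. Compound 2 `O=C(CCCNCCOc1ccc(Oc2c(-c3ccc(F)cc3)sc3cc(O)ccc23)cc1)N1CCC1` reaches only > 25000 nM in this assay, a limit of the assay rather than a number (the limit of > 25000 nM in this assay, at which 1 of the 3 values shown sits). The step of an at least 3.4-fold lower number from compound 2 to compound 3 (0.53 log units; beyond the scatter) sets the chain carrying a double bond apart from the saturated one.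

Compound 4 `C=CC(=O)NCCOc1ccc(Oc2c(-c3ccc(F)cc3)sc3cc(O)ccc23)cc1` differs from compound 3 in one place: vinylcarbonyl in place of 3-((azetidin-1-yl)carbonyl)prop-2-en-1-yl on an amine nitrogen. Among the compounds with values here, no measured step repeats this change. The two steps that bear on it, a 3.0-fold lower number from compound 1 to compound 3 (0.48 log units; beyond the scatter) and an at least 3.4-fold lower number from compound 2 to compound 3 (0.53 log units; beyond the scatter), were each modest and both ended at compound 3, and the vinylcarbonyl that enters keeps a double bond outside aromatic rings. He therefore expects for compound 4 a step of a 1.5-fold lower number from compound 3 to compound 4 (0.17 log units; within the scatter), at most modest and uncertain in direction. His estimate for compound 4 in this assay is 5000 nM, with a range from 1500 nM to 20000 nM.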

Compound 4, half-maximal inhibitory concentration: 23000 nM
Estimate against measurement, compound 4: 4.6-fold (0.66 log units) below; the measured number lies above the stated range.
By their numbers in this assay, from the lowest: compound 3; then compounds 1 and 4 (each within the scatter of the next). At a limit, above all of these: compound 2.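

In this assay vinylcarbonyl in place of 3-((azetidin-1-yl)carbonyl)prop-2-en-1-yl on an amine nitrogen gives a 3.1-fold higher number from compound 3 to compound 4 (0.50 log units; beyond the scatter), although both groups carry the same count of double bonds outside aromatic rings. The step of a 1.0-fold higher number from compound 1 to compound 4 (0.01 log units; within the scatter) places compound 4 level with compound 1, so among the compounds with a number, compound 3 alone stands apart. Compound 2 stands at a limit of the assay and not at a number: the limit of > 25000 nM in this assay, at which 1 of the 4 values shown sits. That limit leaves only an at least 1.0-fold lower number from compound 2 to compound 4 (0.03 log units; that floor lies within the scatter), and no order follows from it.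

On these data alone, whether a pyrrolidine or morpholine amide on the same prop-2-en-1-yl chain would hold the number of compound 3 stays open. So does whether a longer chain between the amine nitrogen and the amide carbonyl would change it.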